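The source may report more compounds than this note shows. Statements on the series, on what has been measured and on what is new or still open speak of the compounds shown alone.

Measured so far in a toxicity assay on THP-1 cells (Homo sapiens) for inhibition; on this read-out lower numbers stand for higher toxicity in this test and higher numbers for lower toxicity in this test:
compound 1 `COc1ccc(-c2cnc(NC(=O)c3ccco3)n2C)cc1` gives > 100000 nM
compound 2 `Cn1c(-c2cccc(Br)c2)cnc1NC(=O)c1ccc(F)cc1` gives > 50000 nM
compound 3 `Cn1c(-c2ccc(Cl)cc2)cnc1NC(=O)c1ncc[nH]1` gives 52000 nM

The value shown for compound 1 is a limit of this assay and not a number; it sits at the limit of > 100000 nM in this assay, at which 1 of the 3 values shown sits. The value of compound 2 is likewise a limit, (the limit of > 50000 nM in this assay, at which 1 of the 3 values shown sits). Only compound 3 gives a number in this assay, 52000 nM. All three compounds read as weakly toxic here. Within the data shown here, no pair among them differs in one place, so no measured step can be read from the set.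

Compound 4 `COc1ccc(-c2cnc(NC(=O)c3ccc(C#N)cc3)n2C)cc1` differs from compound 1 in one place: 4-cyanophenyl in place of furan-2-yl on a carbonyl carbon. The effect of this change is not shown by any measured pair, so no cause can be given for its size. Since the value of compound 1 is a limit and the series as a whole shows little toxicity in this assay, the step from compound 1 to compound 4 is expected to be small, an at least 1.2-fold lower number from compound 1 to compound 4 (0.09 log units; that floor lies within the scatter), not beyond the scatter. For compound 4 the expected value in this assay is 80000 nM, with a range from 20000 nM to 300000 nM, and a further limit reading is considered likely.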

Compound 4, half-maximal cytotoxic concentration: > 100000 nM
Compound 4: no number, only a limit (the forecaster's own chance of this, stated with the estimate: 65%); middle value at least 1.2-fold (0.09 log units) away from the limit.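

In this assay compound 1 and compound 4 both read as a limit and not a number, so no step between them can be read: the limit of > 100000 nM in this assay, at which 2 of the 4 values shown sit.

The compounds shown leave open whether 4-cyanophenyl in place of furan-2-yl on a carbonyl carbon shifts the half-maximal cytotoxic concentration at all.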